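Notes on the aryl substituent step to compound 4

The source may hold more compounds than are shown below. What is called first, only, known or untested is meant among the compounds shown, and "the series" means these compounds.

Among the measured compounds shown here, compound 3 `CC1(C)N=C(N)N=C(N)N1c1ccccc1F` stands second highest of the three numbers known in an assay for inhibition of Dihydrofolate reductase (Bos taurus), at pH 6.25 (on this read-out lower numbers stand for lower potency and higher numbers for higher potency (the scale is a negative logarithm)), where compound 3 gives 4.86. Compound 1 `CSc1ccccc1N1C(N)=NC(N)=NC1(C)C` gives 3.54 in this assay, and compound 2 `CC1(C)N=C(N)N=C(N)N1c1ccccc1S` gives 7.2. All three steps among them are large: a number 3.66 log units higher from compound 1 to compound 2 (beyond the scatter) with hydrogen in place of methyl on a sulfur; a number 1.32 log units higher from compound 1 to compound 3 (beyond the scatter) with fluoro in place of methylsulfanyl on an aromatic carbon; a number 2.34 log units lower from compound 2 to compound 3 (beyond the scatter) with fluoro in place of sulfanyl on an aromatic carbon.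

Compound 4 `CC1(C)N=C(N)N=C(N)N1c1ccccc1Cl` differs from compound 3 by chloro in place of fluoro on an aromatic carbon. For the measured compounds named here, no measured step exchanges one halogen for another. The two steps that touch the fluoro position show that this assay moves strongly when the group there is changed, but both involve sulfur-bearing groups and give no direction for chloro against fluoro. The expected step of a number 0.44 log units higher from compound 3 to compound 4 (beyond the scatter) is therefore set small, with the direction left open and a wide range around it. Compound 4 is estimated at 5.3 in this assay, expected to fall between 4.5 and 6.2.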

Compound 4, logarithm of the reciprocal of the active concentration, log(1/C): 4.86
Beside the measured number, compound 4's estimate is 0.44 log units above it; the range from low to high includes it.
By their numbers in this assay, from the lowest: compound 1; then compounds 3 and 4 (each within the scatter of the next); then compound 2.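

In this assay, the exchange of one halogen for the other on an aromatic carbon ortho to a large group gives no change at the digits printed from compound 3 to compound 4 (within the scatter), so this position, which moved strongly with the sulfur-bearing groups, does not separate chloro from fluoro. Chloro also reproduces the two large steps already seen for fluoro, with a number 2.34 log units lower from compound 2 to compound 4 (beyond the scatter) and a number 1.32 log units higher from compound 1 to compound 4 (beyond the scatter), which places sulfanyl above both halogens and methylsulfanyl below them among these four compounds. Nothing available here accounts for the match between the two halogens or for the wide gap between the two sulfur-bearing groups.

Two halogens are too few to show whether the match extends to bromo or iodo, so the pair cannot yet be read as a general halogen level at this position. As far as these compounds go, it also remains open whether a hydroxyl, an amine or a methyl group in the same place would stand with the halogens, rise towards sulfanyl or fall towards methylsulfanyl.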